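Working notes: from compound 3 to compound 4

The source may hold more compounds than are shown below. What is called first, only, known or untested is meant among the compounds shown, and "the series" means these compounds.

Measured so far in a functional assay on MDA-MB-231 cells (Homo sapiens) for inhibition, read by MTT assay, with a stated time of 48 h (on this read-out lower numbers stand for stronger inhibition and higher numbers for weaker inhibition), as follows
- compound 1 `COc1ccc(N(C)c2nc(C)nc3ccccc23)cc1OCCC[Se]C#N` gives 815 nM
- compound 2 `COc1ccc(N(C)c2nc(C)nc3ccccc23)cc1C(=O)OCC[Se]C#N` gives 1480 nM
- compound 3 `COc1ccc(N(C)c2nc(C)nc3ccccc23)cc1C(=O)OCCC[Se]C#N` gives 1180 nM

Compound 3 stands at 1180 nM in this assay and is not separated from the other two compounds. The data show a 1.3-fold lower number from compound 2 to compound 3 (0.10 log units; within the scatter) and also a 1.4-fold higher number from compound 1 to compound 3 (0.16 log units; within the scatter) in the same series.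

The next compound is compound 4 `COc1ccc(N(C)c2nc(C)nc3ccccc23)cc1C(=O)NCC[Se]C#N`, which has not yet been measured. The structural change is a group of 6 heavy atoms (3 carbon, 2 nitrogen, 1 selenium; no ring) in place of a group of 7 heavy atoms (4 carbon, 1 nitrogen, 1 oxygen, 1 selenium; no ring), on a carbonyl carbon and it sits on a carbonyl carbon whose other neighbours are: aromatic carbon.

Within the data shown here, no measured step makes this exchange on the carbonyl carbon, so the evidence is indirect. The nearest evidence is a 1.3-fold lower number from compound 2 to compound 3 (0.10 log units; within the scatter) as a change on the saturated chain, together with a 1.8-fold higher number from compound 1 to compound 2 (0.26 log units; within the scatter) as a change of the group on an aromatic carbon. Among the measured compounds shown here, neither leaves the scatter, though three compounds are a narrow base and the new group has no measured precedent.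

No step beyond the scatter is therefore expected, and the estimated step is a 1.1-fold higher number from compound 3 to compound 4 (0.04 log units; within the scatter) in this read-out. Compound 4 is estimated at 1300 nM as the expected value, with 550 nM to 3000 nM as its expected range.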

Compound 4, half-maximal inhibitory concentration: 1250 nM
Compound 4: middle estimate off by 1.0-fold (0.02 log units), on the high side; low and high end bracket the measured number.
By their numbers in this assay, from the lowest: compounds 1, 3, 4 and 2 (each within the scatter of the next).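

On the carbonyl carbon, the ester of compound 2 and the amide of compound 4 stay within the scatter in this assay (a 1.2-fold lower number from compound 2 to compound 4 (0.07 log units; within the scatter)), the first sign that this link can change from oxygen to nitrogen without a step beyond the scatter. The exchange of compound 3 for compound 4 brings in a group with 1 hydrogen-bond donor where the group that leaves has none, and it also stays within the scatter (a 1.1-fold higher number from compound 3 to compound 4 (0.03 log units; within the scatter)), as does the move from the aromatic-carbon ether chain of compound 1 (a 1.5-fold higher number from compound 1 to compound 4 (0.19 log units; within the scatter)), so the amide does not separate from the other three compounds on this read-out. Nothing available bears on why these numbers lie so close together.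

Whether a longer chain on the amide nitrogen would leave this narrow band remains open, since only one amide is shown and its chain cannot be compared with another. From the compounds shown here alone, it also remains open whether a carboxylic acid or an amine on the carbonyl carbon, with the selenium and nitrile chain end gone, would show what that chain end contributes in this assay.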